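Aryl swap on the ring nitrogen: compound 3 to compound 4

This account rests on a few compounds, and the source may have more. Where it says the series, first, only, none or still open, it means among the compounds named here.

Measured so far in a functional assay on CHO-K1 cells for agonist activity at Glucose-dependent insulinotropic receptor (Homo sapiens), read by a luciferase reporter, with a stated time of 5 h; on this read-out higher numbers stand for an effect only at larger amounts of compound and lower numbers for an effect already at smaller amounts:
compound 1 `CC(C)OC(=O)N1CCC(Oc2ncnc3c2CCN3c2ccc(S(C)(=O)=O)nc2)CC1` gives 251 nM
compound 2 `CC(C)OC(=O)N1CCC(Oc2ncnc3c2CCN3c2ccc(C#N)cn2)CC1` gives 794 nM
compound 3 `Cc1ncccc1N1CCc2c(OC3CCN(C(=O)OC(C)C)CC3)ncnc21` gives only a limit of the assay, > 10000 nM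

Compound 3 therefore stands at the limit of > 10000 nM in this assay, at which 1 of the 3 values shown sits, with no number of its own, the weakest of the three. The two measured steps that lead to it, an at least 39-fold higher number from compound 1 to compound 3 (1.60 log units; beyond the scatter) and an at least 12-fold higher number from compound 2 to compound 3 (1.10 log units; beyond the scatter), are both large and both reach the limit. Compound 4 `CC(C)OC(=O)N1CCC(Oc2ncnc3c2CCN3c2ccc([S@+](C)[O-])c(F)c2)CC1` changes the same position once more: a group of 10 heavy atoms (7 carbon, 1 oxygen, 1 fluorine, 1 sulfur; one six-membered aromatic ring of carbon only) in place of a group of 7 heavy atoms (6 carbon, 1 nitrogen; one six-membered aromatic ring with 1 hetero atom), on a nitrogen on an aromatic ring in a ring. For the measured compounds named here, no measured step covers this entering group, so its effect is open; the only bearing is that the other two groups at this position in compound 1 and compound 2 were measured at numbers. Compound 4 is expected to come back down from the limit, an at least 16-fold lower number from compound 3 to compound 4 (1.22 log units; beyond the scatter), in the direction of compound 1, with wide uncertainty. For compound 4 the estimate is 600 nM, between 100 nM and 6000 nM.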

Compound 4, half-maximal effective concentration: 50.1 nM
Compound 4: the middle estimate sits 12-fold (1.08 log units) above what was measured, and the stated range ends above it.
By their numbers in this assay, from the lowest: compound 4; then compound 1; then compound 2. At a limit, above all of these: compound 3.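

In this assay, for the compounds shown here, a six-membered aromatic ring of carbon only on the ring nitrogen gives the lowest number so far: a 5.0-fold lower number from compound 1 to compound 4 (0.70 log units; beyond the scatter), and a 16-fold lower number from compound 2 to compound 4 (1.20 log units; beyond the scatter). A single change at this position also carries the series off its poorest point, an at least 190-fold lower number from compound 3 to compound 4 (2.30 log units; beyond the scatter), so a pyridine ring is not required here. The value of compound 3 is a limit, not a number: the limit of > 10000 nM in this assay, at which 1 of the 4 values shown sits.

As far as these compounds go, compound 4 brings the fluorine, sulfur and oxygen in together, so the share of each remains open. Also open, from the compounds shown here alone, are the other form of its stereocentre and what an amine would give on this carbon ring.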